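Swapping Trifluoromethyl for Methoxycarbonyl on a Second Core

This account rests on a few compounds, and the source may have more. Where it says the series, first, only, none or still open, it means among the compounds named here.

Compound 1, `FC(F)(F)c1ccc(CC2CCC3(CC2)OOCCCOO3)cc1`, gives 4.79 in a physicochemical assay for lipophilicity; a lower number here means a more polar compound, a higher number a more lipophilic compound.
Compound 2, `COC(=O)c1ccc(CC2CCC3(CC2)OOCCCOO3)cc1`, gives 3.75 in this assay.
Compound 3, `C=C1COOC2(CCC(Cc3ccc(C(F)(F)F)cc3)CC2)OOC1`, gives 4.95 in this assay.

Between compound 1 and compound 2 a single group is exchanged: methoxycarbonyl in place of trifluoromethyl on an aromatic carbon. That exchange produced a number 1.04 log units lower from compound 1 to compound 2 (beyond the scatter). Compound 3 carries the same trifluoromethyl group on a different core; the difference between the two cores is not broken down here. In this assay compound 3 stands closest to compound 1, within the scatter, and well apart from compound 2.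

Compound 4, `C=C1COOC2(CCC(Cc3ccc(C(=O)OC)cc3)CC2)OOC1`, has not yet been measured. It is related to compound 3 by the same exchange: methoxycarbonyl in place of trifluoromethyl on an aromatic carbon. Going by the values given here, the two places read alike word for word, so this is the same change on a second core, and the single earlier example is all that is known of it. Among the compounds with values here, because the only precedent is a number 1.04 log units lower from compound 1 to compound 2 (beyond the scatter), a step of similar size is expected, namely a number 1.04 log units lower from compound 3 to compound 4 (beyond the scatter). On that basis compound 4 is estimated at 3.91, with a likely range from 3.5 to 4.3.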

Compound 4, partition coefficient: 4.05
The estimate for compound 4 lay 0.14 log units below the measured number; low and high end bracket the measured number.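

In this assay, putting methoxycarbonyl in place of trifluoromethyl on the aromatic carbon gave a number 0.90 log units lower from compound 3 to compound 4 (beyond the scatter), and the same exchange on the other core had given a number 1.04 log units lower from compound 1 to compound 2 (beyond the scatter). The change therefore carried over from one core to the other in direction, and on both cores it moved the number by more than the scatter. This rests on two pairs only, so it shows no general rule for other cores in the series, and nothing measured here explains why the exchange acts as it does on either core.

The compounds shown carry only trifluoromethyl or methoxycarbonyl at this place on the aromatic ring, so a single exchange between these two groups is all that can be followed across the cores. From the compounds shown here alone, whether a carboxylic acid, an amine or a nitrile at the same place would also give matching steps on both cores remains open.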